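This account rests on a few compounds, and the source may have more. Where it says the series, first, only, none or still open, it means among the compounds named here.

Of the compounds shown here, three built on one shared core have so far been measured in an in vitro assay on cells for inhibition of Amine oxidase [flavin-containing] B (Homo sapiens), read by Amplex Red, with a stated time of 15 min; a lower number here means a stronger inhibitor, a higher number a weaker inhibitor. Compound 1 `COc1ccc(/C=C/C=C/C(=O)c2ccccc2O)cc1OC` gives 14600 nM. Compound 2 `O=C(/C=C(O)/C=C/c1ccc(O)c(O)c1)c1ccccc1O` gives 654 nM, and compound 3 `O=C(/C=C(O)/C=C/c1ccccc1)c1ccccc1O` gives 1160 nM. Among these three numbers compound 3 stands second highest; its nearest neighbour is compound 2, whose number lies within the scatter of it, while compound 1 lies beyond the scatter, with a much higher number. Compound 4 `O=C(/C=C(O)/C=C/c1ccc([N+](=O)[O-])cc1)c1ccccc1O` has not yet been measured; it differs from compound 3 by nitro in place of hydrogen on an aromatic carbon. Within the data shown here, no measured pair shows the effect of such a change here, so the expected step is a 1.3-fold lower number from compound 3 to compound 4 (0.11 log units; within the scatter), a small one that should not go beyond the scatter. Compound 4 is therefore estimated to give about 900 nM, within the range 300 nM to 3000 nM.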

Compound 4, half-maximal inhibitory concentration: 2670 nM
For compound 4 the middle estimate is 3.0-fold (0.47 log units) below the measured one; measured number inside the range.
By their numbers in this assay, from the lowest: compounds 2 and 3 (each within the scatter of the next); then compound 4; then compound 1.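

Nitro in place of hydrogen on an aromatic carbon, para to a large group, gives a 2.3-fold higher number from compound 3 to compound 4 (0.36 log units; beyond the scatter) in this assay. Among these compounds, this is the first single change that can be read, and it shows that this position does not accept every group without cost, though the loss is modest. Nothing available gives a reason for this step.

On these data alone, whether an amine or a fluorine atom at the same position would also raise the number stays open. So does the effect of nitro on another carbon of that ring.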